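This account rests on a few compounds, and the source may have more. Where it says the series, first, only, none or still open, it means among the compounds named here.

Of the compounds shown here, two built on the shared core have been measured so far. Compound 1 `Nc1cccc2c(-c3cccc(NC(=O)c4ccc(Cl)c(C(F)(F)F)c4)c3)ccnc12` gives 3300 nM in a functional assay on M14 cells (Homo sapiens) for antiproliferative activity, read by sulforhodamine B assay, with a stated time of 48 h (on this read-out higher numbers stand for weaker inhibition and lower numbers for stronger inhibition), whereas compound 2 `Nc1cccc2c(-c3cccc(NC(=O)c4ccc5c(c4)OCCO5)c3)ccnc12` gives 83 nM in the same assay. Compound 2 therefore stands as the lowest of the two numbers, and the gap to compound 1 lies well beyond the scatter of repeated runs.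

Compound 3 `Nc1cccc2c(-c3cccc(NC(=O)c4nccs4)c3)ccnc12` is the next member of the series and has not yet been measured in this assay. It differs from compound 2 at one site only: 1,3-thiazol-2-yl in place of 2,3-dihydro-1,4-benzodioxin-6-yl on a carbonyl carbon. Because the two measured compounds differ from each other only in the group on that carbonyl carbon and yet show values as far apart as 3300 nM for compound 1 and 83 nM for compound 2, this position evidently decides much of the potency.

Among the measured compounds shown here, the group entering in compound 3 has no counterpart among the measured compounds, so the direction of the step from compound 2 is uncertain. Compound 3 is expected to sit somewhat weaker than compound 2, a step of a 3.6-fold higher number from compound 2 to compound 3 (0.56 log units; beyond the scatter) in this assay. The estimate for compound 3 is 300 nM in this assay, with a range from 60 nM to 2000 nM.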

Compound 3, half-maximal inhibitory concentration: 6900 nM
For compound 3 the middle estimate is 23-fold (1.36 log units) below the measured one, and the stated range ends below it.
By their numbers in this assay, from the lowest: compound 2; then compound 1; then compound 3.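

In this assay, replacing 2,3-dihydro-1,4-benzodioxin-6-yl with 1,3-thiazol-2-yl on a carbonyl carbon gives (an 83-fold higher number from compound 2 to compound 3 (1.92 log units; beyond the scatter)), so the potency of compound 2 is not retained with this five-membered aromatic ring in place of the larger group. The number for compound 3 (6900 nM) is also higher than that for compound 1 (3300 nM), so neither of these groups comes close to the value of compound 2. The two exchanged groups have the same counts of hydrogen-bond donors and acceptors, and no measurement available here accounts for the gap.

On these data alone, it remains open whether two methoxy groups on a phenyl ring, or an unsubstituted phenyl ring, would give numbers close to that of compound 2. The compounds shown also leave open how a pyridine ring, or a methyl group on the 1,3-thiazol-2-yl, would fare at this position.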